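Hydroxy in place of hydroxymethyl: cytotoxicity notes

The source may hold more compounds than are shown below. What is called first, only, known or untested is meant among the compounds shown, and "the series" means these compounds.

In an ADME assay on MT4 cells (Homo sapiens) for cytotoxicity, read by MTT assay (a higher number here means that more compound is tolerated, a lower number that less compound is tolerated), compound 1 (`NC(=O)c1cn([C@H]2C[C@H](O)[C@@H](CO)O2)c(=O)[nH]c1=O`) gives > 200000 nM as a limit of the assay, not a number. Among the compounds with values here, compound 2 (`O=c1[nH]c(=O)n([C@H]2C[C@H](O)[C@@H](CO)O2)cc1CO`) gives 130000 nM as the only number so far. Compound 3 (`O=c1[nH]c(=O)n([C@H]2C[C@H](O)[C@@H](CO)O2)cc1O`) carries hydroxy in place of hydroxymethyl on an aromatic carbon. Within the data shown here, the only measured step, hydroxymethyl in place of carbamoyl on an aromatic carbon, is an at least 1.5-fold lower number from compound 1 to compound 2 (0.18 log units; that floor lies within the scatter) and bears on the same group. No step beyond the scatter is therefore expected in this assay for this change. Compound 3 is estimated at 100000 nM with an expected range from 30000 nM to 200000 nM in this assay. The expected step is a 1.3-fold lower number from compound 2 to compound 3 (0.11 log units; within the scatter) and remains an estimate.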

Compound 3, half-maximal cytotoxic concentration: > 200000 nM
Compound 3 was reported as a limit (the forecaster's own chance of this, stated with the estimate: 25%); middle value at least 2.0-fold (0.30 log units) away from the limit.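

Hydroxy in place of hydroxymethyl on this aromatic carbon gives an at least 1.5-fold higher number from compound 2 to compound 3 (0.18 log units; that floor lies within the scatter), so a group of one heavy atom here brings no lower number in this assay. The step from compound 1 to compound 3 cannot be read, as both values are limits. Compound 2 alone gives a number, so the readings at this position are capped: the limit of > 200000 nM in this assay, at which 2 of the 3 values shown sit.

Open, from the compounds shown here alone, is whether an amine, a carboxylic acid or a longer chain on this aromatic carbon would give a number beyond the scatter from compound 2. Going by these compounds, how far compound 1 and compound 3 lie apart also stays open.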